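Benzothiophene carbonyl in place of difluorophenyl: cytotoxicity notes

This account rests on a few compounds, and the source may have more. Where it says the series, first, only, none or still open, it means among the compounds named here.

Of the compounds shown here, three have been measured in an ADME assay on MT4 cells (Homo sapiens) for cytotoxicity, read by MTT assay; a higher number here means that more compound is tolerated, a lower number that less compound is tolerated. Compound 1 `Cc1ccc(N(C(=O)c2ccccc2C)C(=S)OCCN2C(=O)c3ccccc3C2=O)cc1` gives only a limit in this assay, > 100000 nM. Compound 2 `O=C1c2ccccc2C(=O)N1CCOC(=S)N(C(=O)c1ccc(F)c(F)c1)c1ccc(Cl)cc1` gives 52000 nM in this assay, and compound 3 `Cc1ccc(N(C(=O)c2c(F)cccc2F)C(=S)OCCN2C(=O)c3ccccc3C2=O)cc1` gives 65000 nM. On the numbers shown, compound 2 holds the lowest of the two numbers, but its gap to compound 3 lies within the scatter, so the two cannot be set apart. Among the compounds with values here, the only step measured at the carbonyl carbon, an at least 1.5-fold lower number from compound 1 to compound 3 (0.18 log units; that floor lies within the scatter), starts from a limit of > 100000 nM in this assay, at which 1 of the 3 values shown sits, and its floor sits within the scatter.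

Compound 4 `O=C1c2ccccc2C(=O)N1CCOC(=S)N(C(=O)c1cc2ccccc2s1)c1ccc(Cl)cc1` is not yet measured. It differs from compound 2 by 1-benzothiophen-2-yl in place of 3,4-difluorophenyl on a carbonyl carbon. Within the data shown here, no measured step involves a 1-benzothiophen-2-yl group; the one step at the same place, 2-methylphenyl to 2,6-difluorophenyl, is itself within the scatter. The measured steps therefore give no ground to expect a shift beyond the scatter in this assay, in either direction. Compound 4 is expected to give about 40000 nM in this assay, between 15000 nM and 100000 nM. That estimate means an expected step of a 1.3-fold lower number from compound 2 to compound 4 (0.11 log units; within the scatter).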

Compound 4, half-maximal cytotoxic concentration: 56000 nM
Estimate against measurement, compound 4: 1.4-fold (0.15 log units) below; the measured number falls inside the stated range.
By their numbers in this assay, from the lowest: compounds 2, 4 and 3 (each within the scatter of the next). At a limit, above all of these: compound 1.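

In this assay, within the data shown here, a 1.1-fold higher number from compound 2 to compound 4 (0.03 log units; within the scatter) is the first step at this carbonyl carbon with a number at both ends, whereas the earlier step from 2-methylphenyl to 2,6-difluorophenyl starts from a limit. In this one pair, 1-benzothiophen-2-yl, with its five-membered aromatic ring holding sulfur, takes the place of 3,4-difluorophenyl, with its two fluorine atoms, without a change that can be told from the scatter, so this position accepts a two-ring group on the shared core with no readable shift in this assay. Compound 4 gives a number and not a limit, so its step can be read in full, and the only limit in the series remains that of compound 1: the limit of > 100000 nM in this assay, at which 1 of the 4 values shown sits.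

All the groups shown at this carbonyl carbon are aromatic rings, so how an amine, a carboxylic acid or an open alkyl chain there would read in this assay remains open. Also open, on these data alone, is whether 1-benzothiophen-2-yl would read the same way on the core of compound 1 or compound 3, which differs from that of compound 2 at the amide-type nitrogen.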